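Swapping the Aryl Group on the Shared Core

The compounds below may be only part of what the source reports. "The series", "measured", "known", "first", "only" and "open" are said of these compounds alone.

Compound 1 `O=C1/C(=C\c2ccc(Cl)cc2)S/C(=N/c2ccccc2)N1Cc1ccncc1`: 54900 nM
Compound 2 `COc1cc(/C=C2/S/C(=N/c3ccccc3)N(Cc3ccncc3)C2=O)ccc1O`: 28000 nM

In a functional assay on MCF7 cells (Homo sapiens) for cytotoxicity, read by MTT assay, with a stated time of 48 h (a lower number here means a stronger inhibitor, a higher number a weaker inhibitor), compound 1 gives 54900 nM, the highest of the two numbers. Compound 2 gives 28000 nM, and the step of a 2.0-fold lower number from compound 1 to compound 2 (0.29 log units; within the scatter) lies within the scatter. Compound 3 `COc1ccc(OC)c(/C=C2/S/C(=N/c3ccccc3)N(Cc3ccncc3)C2=O)c1` differs from compound 1 by 2,5-dimethoxyphenyl in place of 4-chlorophenyl on a double-bonded chain carbon bound to a double-bonded ring carbon. Among the compounds with values here, the only measured step at this place, a 2.0-fold lower number from compound 1 to compound 2 (0.29 log units; within the scatter), exchanged the same group and stayed within the scatter, so for compound 3 no step beyond the scatter is expected, a 1.4-fold lower number from compound 1 to compound 3 (0.14 log units; within the scatter). Compound 3 is therefore estimated at 40000 nM, with a range from 15000 nM to 110000 nM.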

Compound 3, half-maximal inhibitory concentration: 37000 nM
The estimate for compound 3 lay 1.1-fold (0.03 log units) above the measured number; low and high end bracket the measured number.
By their numbers in this assay, from the lowest: compounds 2, 3 and 1 (each within the scatter of the next).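

In this assay, 2,5-dimethoxyphenyl in place of 4-chlorophenyl gives a 1.5-fold lower number from compound 1 to compound 3 (0.17 log units; within the scatter), and in place of 4-hydroxy-3-methoxyphenyl it gives a 1.3-fold higher number from compound 2 to compound 3 (0.12 log units; within the scatter). All three aryl groups at this place therefore give numbers within the scatter of the next, so this third exchange adds no measurable difference. Nothing available explains this result.

The compounds shown leave open whether an amine or a carboxylic acid on this phenyl ring, or a longer alkyl chain in place of the ring, would produce a step beyond the scatter.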